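The source may report more compounds than this note shows. Statements on the series, on what has been measured and on what is new or still open speak of the compounds shown alone.

Three closely related compounds have been measured in a functional assay on V79-379A cells (Cricetulus griseus) for cytotoxicity, read by MTT assay, in the presence of a further agent that is not named here; a higher number here means a weaker inhibitor, a lower number a stronger inhibitor. Compound 1 (`COC1=CC(=O)c2c(c(COC(=O)c3ccc(F)cc3)cn2C)C1=O`) gives 700 nM, and compound 3 (`COC1=CC(=O)c2c(c(COc3c(Cl)cc(Cl)cc3Cl)cn2C)C1=O`) gives 700 nM. Compound 2 (`COC1=CC(=O)c2c(c(COCc3ccccc3)c(C)n2C)C1=O`) gives 225000 nM, the highest of the three numbers and beyond the scatter from both of the others.

Compound 4 (`COC1=CC(=O)c2c(c(COC(N)=O)c(C)n2C)C1=O`) departs from compound 2 in one place: carbamoyl in place of benzyl on an oxygen on a saturated carbon. In words, carbamoyl stands in place of benzyl on an oxygen on a saturated carbon. For the measured compounds named here, no measured pair isolates this change, since compound 1 and compound 3 each differ from compound 2 in more than one place. Going by the values given here, the only guide is the spread of values: compound 2 at 225000 nM sits far from compound 1 at 700 nM and compound 3 at 700 nM. A lower number beyond the scatter is therefore expected, though with wide uncertainty, and a full drop to the level of those two is not assumed. The estimated change is a 23-fold lower number from compound 2 to compound 4 (1.35 log units; beyond the scatter). For compound 4 the expected value is 10000 nM, with an estimated range of 1000 nM to 100000 nM.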

Compound 4, half-maximal inhibitory concentration: 25000 nM
Compound 4: middle estimate off by 2.5-fold (0.40 log units), on the low side; the range from low to high includes it.
By their numbers in this assay, from the lowest: compounds 1 and 3 (each within the scatter of the next); then compound 4; then compound 2.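

On an oxygen on a saturated carbon, carbamoyl in place of benzyl gives a 9.0-fold lower number from compound 2 to compound 4 (0.95 log units; beyond the scatter) in this assay, the first single-place change read directly, and it shows that the group held here alters the number beyond the scatter. The change removes an aromatic ring and brings in a hydrogen-bond donor and acceptor, but this one step cannot separate those differences from one another or from the drop in heavy atoms. No measurement at hand explains the size of the step.

As far as these compounds go, it remains open whether acetyl, which has a carbonyl but no amide hydrogen, would give a number closer to that of compound 4 or compound 2. For the compounds shown here, no single-place step links compound 4 to compound 1 or compound 3, so how carbamoyl compares with their groups stays unread.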